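The source may report more compounds than this note shows. Statements on the series, on what has been measured and on what is new or still open speak of the compounds shown alone.

Measured so far in a functional assay on CFPAC-1 cells (Homo sapiens) for antiproliferative activity, read by MTT assay, with a stated time of 72 h; on this read-out higher numbers stand for weaker inhibition and lower numbers for stronger inhibition:

- compound 1 `C[Si](C)(C)c1cn(C[C@H](O)[C@H]2OC(=O)C(OCc3ccccc3)=C2OCc2ccccc2)nn1` gives 52600 nM
- compound 2 `O=C1O/C(=C\Cn2cc(-c3cccc(O)c3)nn2)C(OCc2ccccc2)=C1OCc1ccccc1` gives 33700 nM
- compound 3 `O=C1O/C(=C\Cn2cc(-c3cc(C(F)(F)F)cc(C(F)(F)F)c3)nn2)C(OCc2ccccc2)=C1OCc1ccccc1` gives only a limit of the assay, > 100000 nM (the limit of > 100000 nM in this assay, at which 1 of the 3 values shown sits)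

Compound 1 stands at the highest of the two numbers shown, but compound 2 lies within the usual scatter of it, so the two are not told apart, and compound 3 supplies no number at all. Among the compounds with values here, no pair among the measured compounds differs in a single place, so no measured step is available for guidance.

The compound still to be measured, compound 4 `CCCCc1cn(C[C@H](O)[C@H]2OC(=O)C(OCc3ccccc3)=C2OCc2ccccc2)nn1`, differs from compound 1 at one place: a group of 4 heavy atoms (4 carbon; no ring) in place of a group of 4 heavy atoms (3 carbon, 1 silicon; no ring), on an aromatic carbon. Within the data shown here, the data give no step of this kind, and so the expectation is that the change from compound 1 to compound 4 brings no shift beyond the scatter in this assay, that is, an expected step of a 1.1-fold lower number from compound 1 to compound 4 (0.02 log units; within the scatter). Compound 4 is therefore estimated at 50000 nM, with a range from 20000 nM to 100000 nM.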

Compound 4, half-maximal inhibitory concentration: 73200 nM
Compound 4: the middle estimate sits 1.5-fold (0.17 log units) below what was measured; measured number inside the range.
By their numbers in this assay, from the lowest: compounds 2, 1 and 4 (each within the scatter of the next, the first and the last beyond it). At a limit, above all of these: compound 3.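

In this assay, within the data shown here, the exchange of the silicon-bearing group for butyl on this aromatic carbon of the five-membered ring gives the first single-place step: a 1.4-fold higher number from compound 1 to compound 4 (0.14 log units; within the scatter). At this position, then, an all-carbon butyl chain can stand in for the group with silicon, with the same count of heavy atoms, without a shift that can be told from the scatter. No measurement shown here bears on the cause of this step.

As far as these compounds go, whether an amine, a carboxylic acid or a longer chain on the same carbon would move the number beyond the scatter remains open. Also open, from the compounds shown here alone, is whether this exchange would read the same on the core of compound 2, which differs from compound 1 in more than one place.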